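A few compounds are considered here, and "the series" means these few. Any claim that something is new, unique, unknown or untested is made for them only; others in the source may bear on it.

Measured so far in an assay on isolated protein for inhibition of DNA topoisomerase 1 (Homo sapiens), with a stated time of 15 min, tested at 200 uM; on this read-out lower numbers stand for less inhibition and higher numbers for more inhibition at the one concentration tested (going by the name of the read-out):

Compound 1 `COc1c(NCCN)c(F)cc2c(=O)c(C(=O)O)cn(Cc3ccc(-c4ccccc4)cc3)c12` gives 10%.
Compound 2 `NC[C@@H]1CCN(c2cc3c(cc2F)c(=O)c(C(=O)O)cn3Cc2nc(-c3ccncc3)no2)C1` gives 10%.
Compound 3 `CNCCCCNc1c(F)cc2c(=O)c(C(=O)O)cn(Cc3ccc(-c4ccccc4)cc3)c2c1OC` gives 10%.

Compound 1 therefore stands level with compound 2 and compound 3; all three sit at the same low reading within the scatter of this assay. Compound 4 `COc1c(F)c(F)cc2c(=O)c(C(=O)O)cn(Cc3ccc(-c4ccccc4)cc3)c12` has not been measured. It differs from compound 1 by fluoro in place of (2-aminoethyl)amino on an aromatic carbon. Among the compounds with values here, only one measured step touches that part of the molecule: no change at the digits printed from compound 1 to compound 3 (within the scatter), where the chain was lengthened and nothing moved. Within the data shown here, no measured step removes the chain altogether, so the expectation rests on that single step alone. The estimated step is no change at the digits printed from compound 1 to compound 4 (within the scatter), none beyond the scatter. Compound 4 is expected to give about 10%, with a range from 0% to 25%.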

Compound 4, a percentage reported as inhibition, at one concentration (the size of the read-out at that concentration, not a potency): "not active" (no number reported)
For compound 4 the study gives words and no number, so the estimate cannot be set against anything.
By their numbers in this assay, from the lowest: compounds 1, 2 and 3 (each within the scatter of the next).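

Within the data shown here, compound 4 is reported in this assay only as "not active", without a number, so no step from compound 1 to compound 4 can be read. No supporting data bear on this result. The compounds shown leave open whether replacing (2-aminoethyl)amino with fluoro changes inhibition at all.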